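The compounds below may be only part of what the source reports. "The series", "measured", "known", "first", "only" and "open" are said of these compounds alone.

Measured so far:
compound 1, `O=C(COc1ccc(CNC2CC=C(c3c[nH]c4ccc(F)cc34)CC2)c(F)c1)NO`: 1420 nM
compound 2, `O=C(COc1ccc(CNC2CC=C(c3c[nH]c4ccccc34)CC2)c(F)c1)NO`: 1170 nM
compound 3, `Cc1[nH]c2cccc(F)c2c1C1=CCC(NCc2ccc(OCC(=O)NO)cc2F)CC1`: 1180 nM

These compounds were tested in a functional assay on MCF7 cells (Homo sapiens) for antiproliferative activity, with a stated time of 72 h; on this read-out lower numbers stand for stronger inhibition and higher numbers for weaker inhibition. Compound 1 and compound 2 differ in one place, (hydrogen in place of fluoro on an aromatic carbon), and the step was a 1.2-fold lower number from compound 1 to compound 2 (0.08 log units; within the scatter). Compound 3 carries a different core, and the difference between the two cores is not broken down here; its value and that of compound 2 fall within the scatter of each other. Compound 4, `Cc1[nH]c2ccccc2c1C1=CCC(NCc2ccc(OCC(=O)NO)cc2F)CC1`, has not been measured. It differs from compound 3 by hydrogen in place of fluoro on an aromatic carbon, the same kind of change as from compound 1 to compound 2, though the fluorine sits ortho and meta to the fused ring rather than meta and para. Because compound 1 to compound 2 gave a 1.2-fold lower number from compound 1 to compound 2 (0.08 log units; within the scatter), the expected step is a 1.1-fold lower number from compound 3 to compound 4 (0.05 log units; within the scatter), and compound 4 is estimated at 1050 nM, between 500 nM and 2200 nM.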

Compound 4, half-maximal inhibitory concentration: 912 nM
Compound 4: middle estimate off by 1.2-fold (0.06 log units), on the high side; the measured number falls inside the stated range.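

In this assay, putting hydrogen in place of fluoro on an aromatic carbon gives a similar small step on both cores, a 1.3-fold lower number from compound 3 to compound 4 (0.11 log units; within the scatter) on the newer one, and the two steps match: the same change on two cores in this assay, a 1.2-fold lower number (0.08 log units; within the scatter) from compound 1 to compound 2 and a 1.3-fold lower number (0.11 log units; within the scatter) from compound 3 to compound 4, 1.1-fold (0.03 log units) apart, within the scatter of two such steps. The other steps, a 1.3-fold lower number from compound 2 to compound 4 (0.11 log units; within the scatter) and a 1.6-fold lower number from compound 1 to compound 4 (0.19 log units; within the scatter), are also within the scatter. This shows that the swap leaves the number essentially unmoved on these two cores, but it does not show that the change would carry over to other cores, or that it would carry over in the same way where it has a clear effect.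

The compounds shown leave open whether a methoxy group, an amine or a carboxylic acid on that aromatic carbon would give a step beyond the scatter. They also leave open whether a longer chain in place of the methyl group would do so.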